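Working notes: carboxy removal in a small antiproliferative series

The source may hold more compounds than are shown below. What is called first, only, known or untested is meant among the compounds shown, and "the series" means these compounds.

Measured so far in a functional assay on KB cells (Homo sapiens) for antiproliferative activity, read by MTT assay, with a stated time of 72 h; a higher number here means a weaker inhibitor, a lower number a stronger inhibitor:
Compound 1 `COc1ccc(-c2sc(C(=O)O)cc2-c2cc(OC)c(OC)c(OC)c2)cc1` gives 10400 nM.
Compound 2 `COc1cc(-c2cc(C(=O)O)sc2-c2ccc3ccccc3c2)cc(OC)c1OC` gives 5640 nM.
Compound 3 `COc1ccc(-c2sccc2-c2cc(OC)c(OC)c(OC)c2)cc1` gives 8880 nM.

Compound 4 `COc1cc(-c2ccsc2-c2ccc3ccccc3c2)cc(OC)c1OC` is not yet measured. It differs from compound 2 by hydrogen in place of carboxy on an aromatic carbon. The same kind of change, (hydrogen in place of carboxy on an aromatic carbon), has been made once already between measured compounds, with a step of a 1.2-fold lower number from compound 1 to compound 3 (0.07 log units; within the scatter). The two cores differ by naphthalen-2-yl in place of 4-methoxyphenyl on an aromatic carbon, so the surroundings of the place are not identical: in one case a ring atom two ring bonds away bears a 4-methoxyphenyl group, in the other a naphthalen-2-yl group. The step of a 1.8-fold lower number from compound 1 to compound 2 (0.27 log units; within the scatter) is also small. For compound 4 the expected step is a 1.2-fold lower number from compound 2 to compound 4 (0.08 log units; within the scatter), because of a 1.2-fold lower number from compound 1 to compound 3 (0.07 log units; within the scatter). Compound 4 is therefore estimated at 4700 nM, between 2000 nM and 12000 nM.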

Compound 4, half-maximal inhibitory concentration: 3660 nM
The estimate for compound 4 lay 1.3-fold (0.11 log units) above the measured number, and the stated range covers the measured number.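

In this assay, hydrogen in place of carboxy on an aromatic carbon gives a 1.5-fold lower number from compound 2 to compound 4 (0.19 log units; within the scatter). Set beside the earlier case, the change carries from one core to the other without a difference that can be told from the scatter: the same change on two cores in this assay, a 1.2-fold lower number (0.07 log units; within the scatter) from compound 1 to compound 3 and a 1.5-fold lower number (0.19 log units; within the scatter) from compound 2 to compound 4, 1.3-fold (0.12 log units) apart, within the scatter of two such steps. This supports only a small step on these two cores, one bearing 4-methoxyphenyl and the other naphthalen-2-yl; it gives no direction for the change and does not show that the result holds on any other core.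

Still open, going by these compounds, is how an amide, a methyl ester or an amine would read at the same place, next to the ring sulfur. Also open, on these data alone, is whether a longer chain there would leave the number within the scatter.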